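Fluorophenyl in Place of Dimethoxyphenyl, Awaiting Measurement

This account rests on a few compounds, and the source may have more. Where it says the series, first, only, none or still open, it means among the compounds named here.

Compound 2 `COc1ccc(CNc2nc3cc(N)cc(N)c3nc2-c2ccccc2)cc1OC` carries the larger of the two numbers recorded in a functional assay on Hs-578T cells (Homo sapiens) for inhibition, read by sulforhodamine B assay, with a stated time of 48 h (on this read-out lower numbers stand for stronger inhibition of growth and higher numbers for weaker inhibition of growth), where compound 2 gives 33900 nM. In this assay compound 1 `Nc1cc(N)c2nc(-c3ccccc3)c(Oc3ccc(F)cc3)nc2c1` gives 20000 nM, and the gap between the two lies within the scatter, so they cannot be told apart. Compound 3 `Nc1cc(N)c2nc(-c3ccccc3)c(NCc3ccc(F)cc3)nc2c1` differs from compound 2 in one place: 4-fluorophenyl in place of 3,4-dimethoxyphenyl on a saturated chain carbon bound to a nitrogen on an aromatic ring. For the measured compounds named here, no measured pair shows this change, so only a step of about a 1.4-fold lower number from compound 2 to compound 3 (0.13 log units; within the scatter) is expected, not beyond the scatter, partly because compound 1 with its own 4-fluorophenyl gives 20000 nM. Compound 3 is estimated at 25000 nM, within a range from 8000 nM to 80000 nM.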

Compound 3, concentration for 50% growth inhibition: 4900 nM
Compound 3: the middle estimate sits 5.1-fold (0.71 log units) above what was measured; the whole stated range lies above it.
By their numbers in this assay, from the lowest: compound 3; then compounds 1 and 2 (each within the scatter of the next).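

In this assay this position responds to its group: 4-fluorophenyl in place of 3,4-dimethoxyphenyl brings a 6.9-fold lower number from compound 2 to compound 3 (0.84 log units; beyond the scatter) and so opens a gap that the two earlier compounds, within the scatter of each other, did not show. The link to the core counts too: (4-fluorobenzyl)amino in place of 4-fluorophenoxy on an aromatic carbon brings a 4.1-fold lower number from compound 1 to compound 3 (0.61 log units; beyond the scatter) with the 4-fluorophenyl kept. Nothing available here explains either step.

Still open, as far as these compounds go, is whether a longer chain carrying the 4-fluorophenyl would lower the number further. The same question stands for a carboxylic acid or an amine in place of that ring.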